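A Fluorophenyl Swap on a Compound at the Limit

The source may hold more compounds than are shown below. What is called first, only, known or untested is meant among the compounds shown, and "the series" means these compounds.

In an ADME assay on MCF-10A cells (Homo sapiens) for inhibition, with a stated time of 48 h (a lower number here means a stronger inhibitor, a higher number a weaker inhibitor), compound 3 (`O=C(Nc1ccc(Cl)cc1)N1CCC[C@H]1c1nc(-c2ccccc2Br)no1`) gives > 50000 nM, which is a limit and not a number. Compound 1 (`O=C(Nc1ccc(Br)cc1)N1CCC[C@H]1c1nc(-c2ccccc2)no1`) gives > 50000 nM, also a limit. Compound 2 (`O=C(Nc1ccc([N+](=O)[O-])cc1)N1CCC[C@H]1c1nc(-c2ccccc2)no1`) gives > 50000 nM, again a limit.

Compound 4 (`O=C(Nc1ccc(Cl)cc1)N1CCC[C@H]1c1nc(-c2ccc(F)cc2)no1`) carries 4-fluorophenyl in place of 2-bromophenyl on an aromatic carbon of a five-membered aromatic ring with 2 nitrogen and 1 oxygen: 4-fluorophenyl in place of 2-bromophenyl on an aromatic carbon.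

Among the measured compounds shown here, only one measured step is available, with nitro in place of bromo on an aromatic carbon: a step that the two limits leave unreadable from compound 1 to compound 2. It is a different change, and it gives no size to carry over. What remains is the limit of > 50000 nM in this assay, at which 3 of the 3 values shown sit.

The expectation therefore rests on compound 3 at > 50000 nM, a limit. A change beyond the scatter in this assay is not expected, and the estimate is a number no higher from compound 3 to compound 4 (the limit leaves the size open). Compound 4 is expected to be reported at the same limit. For compound 4 the estimated value is 50000 nM, with an expected range from 20000 nM to 100000 nM.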

Compound 4, half-maximal inhibitory concentration: > 50000 nM
Compound 4: only a limit was reported (the forecaster's own chance of this, stated with the estimate: 85%); the middle value sits exactly at the limit.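

No size can be read for the change from compound 3 to compound 4 in this assay, as both compounds are reported only as limits: the limit of > 50000 nM in this assay, at which 4 of the 4 values shown sit.

The compounds shown leave open how these structures rank against one another in this assay, and whether any change on the shared core would give a measured number.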